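A few compounds are considered here, and "the series" means these few. Any claim that something is new, unique, unknown or untested is made for them only; others in the source may bear on it.

Measured compounds:
Compound 1, `Cc1cc(Cl)cc2nc(N3CCN(C)CC3)oc12`, gives 6.7 in a functional assay on ileum (strain Hartley) for agonist activity at 5-hydroxytryptamine receptor 3A (Cavia porcellus); a lower number here means a less potent compound, a higher number a more potent compound, by a factor of ten per unit of this negative logarithm.
Compound 2, `CN1CCN(c2nc3cc(C(F)(F)F)ccc3o2)CC1`, reaches only a limit of the assay, < 4, and not a number.
Compound 3, `COc1cccc2nc(N3CCN(C)CC3)oc12`, likewise sits at a limit, < 4, not at a measured number.

Compound 2 therefore stands at the bottom of what this assay can report, and it shares that position with another compound: the limit of < 4 in this assay, at which 2 of the 3 values shown sit. Only compound 1 shows a numerical value, and no pair of these compounds differs in a single place, so no measured step is available.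

Compound 4, `CN1CCN(c2nc3cc(C(C)(C)C)ccc3o2)CC1`, has not been measured. It differs from compound 2 by tert-butyl in place of trifluoromethyl on an aromatic carbon. Among the measured compounds shown here, with no measured step to lean on, the size of the change from compound 2 to compound 4 is unknown; both groups are uncharged and carry no hydrogen-bond donors or acceptors. The expected step of a number at least 0.40 log units higher from compound 2 to compound 4 (beyond the scatter) is modest, possibly leaving the compound near the limit. Compound 4 is estimated at 4.4, with a range from 3.4 to 5.4.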

Compound 4, negative logarithm of the half-maximal effective concentration: < 4
Compound 4 ended at the assay's limit (the forecaster's own chance of this, stated with the estimate: 50%); middle value at least 0.40 log units away from the limit.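

Compound 2 and compound 4 both sit at a limit of this assay and give no number, so no step can be read between them: the limit of < 4 in this assay, at which 3 of the 4 values shown sit.

The compounds shown leave open whether tert-butyl and trifluoromethyl in this place differ in potency at all, and by how much.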